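This account rests on a few compounds, and the source may have more. Where it says the series, first, only, none or still open, it means among the compounds named here.

Working notes on the series.

Compound 1 `COc1ccc(Cl)cc1C(=O)NCCC1CCN(S(=O)(=O)NC(=O)NC[C@@H]2C[C@@H]3C=C[C@@H]2C3)CC1` is the reference point. Among the measured compounds shown here, in a functional assay on the whole organism (blood) with Rattus norvegicus as the target, with stated times of 24 h and 1 h, at a dose of 5 mg/kg by the intraperitoneal route (a higher number here means a stronger effect of the compound at the dose given, a lower number a weaker effect), compound 1 gives 37%, which stands as the higher of the two numbers measured so far. Compound 2 `CCCNC(=O)NS(=O)(=O)N1CCC(CCNC(=O)c2cc(Cl)ccc2OC)CC1` carries a propyl in place of the bicyclic group on the urea side; in this assay compound 2 gives 11%, and the step of a number 26 percentage points lower from compound 1 to compound 2 (beyond the scatter) is beyond the scatter.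

Compound 3 `O=C(NC[C@@H]1C[C@@H]2C=C[C@@H]1C2)NS(=O)(=O)N1CCC(CCNC(=O)c2cc(Cl)cc3cccnc23)CC1` differs from compound 1 at the other end of the molecule: 6-chloroquinolin-8-yl in place of 5-chloro-2-methoxyphenyl on a carbonyl carbon. For the measured compounds named here, no measured step touches the aryl group on the carbonyl carbon; the only step available, a number 26 percentage points lower from compound 1 to compound 2 (beyond the scatter), concerns the group on the saturated chain carbon bound to the amide-type nitrogen and so does not bear on this change. The direction and size of a number 2 percentage points lower from compound 1 to compound 3 (within the scatter) are therefore expected without guidance from the two measured compounds. For compound 3 a reading near that of compound 1 is estimated, 35%, within a wide range from 10% to 60%.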

Compound 3, a percentage reported as activity, at one dose (the size of the read-out at that dose, not a potency): 35%
Estimate against measurement, compound 3: no gap at the digits printed; the measured number falls inside the stated range.
By their numbers in this assay, from the lowest: compound 2; then compounds 3 and 1 (each within the scatter of the next).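

In this assay, among the compounds shown here, the first change at the aryl group on the carbonyl carbon gives a number 2 percentage points lower from compound 1 to compound 3 (within the scatter), so compound 1 and compound 3 stand level. At this place, then, 6-chloroquinolin-8-yl, with its second aromatic ring and ring nitrogen and no methoxy, serves as well as 5-chloro-2-methoxyphenyl, whereas the change on the saturated chain carbon bound to an amide-type nitrogen gave a number 26 percentage points lower from compound 1 to compound 2 (beyond the scatter). The data on hand offer no explanation for this match between the two aryl groups.

On these data alone, whether 6-chloroquinolin-8-yl would hold its reading alongside the propyl of compound 2 remains open. Also open, as far as these compounds go, is how far this tolerance extends, for instance to a plain phenyl without chlorine or to an aryl group carrying an amine or a carboxylic acid.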